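Swapping Phenoxy for Dimethylamino: An Expected Cell Value

A few compounds are considered here, and "the series" means these few. Any claim that something is new, unique, unknown or untested is made for them only; others in the source may bear on it.

Two compounds measured in a functional assay on COLO 205 cells (Homo sapiens) for inhibition, read by sulforhodamine B assay, with a stated time of 48 h (a higher number here means that more compound is tolerated, a lower number that less compound is tolerated), set the frame. Compound 1 `COc1cc(C)cc(-c2nn(CC#N)cc2-c2ccc(-c3cccc(C(C)=O)c3)nc2)c1` gives 9200 nM in this assay. Compound 2 `Cc1cc(O)cc(-c2nn(CC#N)cc2-c2ccnc(-c3ccc(Oc4ccccc4)cc3)c2)c1` gives 5900 nM in this assay. Compound 2 holds the lower of the two numbers, but compound 1 sits so close to it that the two values lie within the usual scatter of each other, and no order between them can be claimed.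

Compound 3 `Cc1cc(O)cc(-c2nn(CC#N)cc2-c2ccnc(-c3ccc(N(C)C)cc3)c2)c1` has not yet been measured. It differs from compound 2 in one place: dimethylamino in place of phenoxy on an aromatic carbon. Among the compounds with values here, no measured pair in this set shows what such a change does, so there is nothing to point in either direction. The expected step is therefore a 1.2-fold higher number from compound 2 to compound 3 (0.07 log units; within the scatter), which amounts to no movement beyond the scatter. For compound 3 the value is estimated at 7000 nM, with a range from 2500 nM to 20000 nM that reflects how little the measured data constrain this exchange.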

Compound 3, concentration lethal to 50% of the cells: 87800 nM
For compound 3 the middle estimate is 13-fold (1.10 log units) below the measured one, and the stated range ends below it.
By their numbers in this assay, from the lowest: compounds 2 and 1 (each within the scatter of the next); then compound 3.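

The exchange of phenoxy for dimethylamino on this aromatic carbon, para to a large group, gives a 15-fold higher number from compound 2 to compound 3 (1.17 log units; beyond the scatter) in this assay, so this position is not indifferent to what it carries, and more compound is tolerated with dimethylamino there. The two groups have the same counts of hydrogen-bond donors and acceptors and neither bears a net charge, whereas phenoxy brings more heavy atoms and a six-membered aromatic ring of carbon only, so these are the computed differences that accompany the step, though a single pair cannot show that either one accounts for it. Nothing measured here gives a reason for the size of this step.

The compounds shown leave open whether the ring, the size of the group or the atom joining it to the aromatic carbon matters most, and a methoxy group or a phenylamino group at this place would begin to separate these. They also leave open whether a small unbranched amine, such as methylamino, would stay with dimethylamino, or whether the same exchange would give a step of similar size on a different core.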